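The source may hold more compounds than are shown below. What is called first, only, known or untested is meant among the compounds shown, and "the series" means these compounds.

Three compounds of this series have been run in a functional assay on HCT-116 cells (Homo sapiens) for cytotoxicity, with a stated time of 3 days; a lower number here means a stronger inhibitor, a higher number a weaker inhibitor. Compound 1 `Brc1nc2ccccc2[se]1` gives only a limit of the assay, > 40000 nM. Compound 3 `c1ccc2[se]cnc2c1` likewise gives only a limit, > 40000 nM. The step that the two limits leave unreadable from compound 1 to compound 3 is hydrogen in place of bromo on an aromatic carbon. Compound 2 `C#CCNC(=O)c1csc(Br)n1` also gives only a limit, > 40000 nM. The difference between the core of compound 2 and the core of compound 1 is not broken down here. Compound 4 `C#CCNC(=O)c1cscn1` is not yet measured in this assay and differs from compound 2 by hydrogen in place of bromo on an aromatic carbon, the same kind of change as from compound 1 to compound 3, though here the ring holds 1 nitrogen and 1 sulfur, is not part of a fused system, and the site lies two ring bonds from the ring atom that bears a group of 6 heavy atoms. Within the data shown here, because the limit of > 40000 nM in this assay, at which 3 of the 3 values shown sit, holds every value so far, compound 4 is expected to give 60000 nM in this assay, between 25000 nM and 250000 nM. The expected step is a step that the limit leaves unreadable from compound 2 to compound 4.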

Compound 4, half-maximal inhibitory concentration: > 40000 nM
Compound 4: only a limit was reported; the forecaster's own chance of this, stated with the estimate: 85%; the middle value is on the limit's open side.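

No step can be read between compound 2 and compound 4 in this assay, as both give only a limit: the limit of > 40000 nM in this assay, at which 4 of the 4 values shown sit.

The compounds shown leave open whether hydrogen in place of bromo changes cytotoxicity on either core.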